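Replacing dimethylamino by (2-hydroxyethyl)amino on two related cores

The source may report more compounds than this note shows. Statements on the series, on what has been measured and on what is new or still open speak of the compounds shown alone.

Measured in a functional assay (Homo sapiens) for inhibition of Nucleic Acid, tested at 100 uM; on this read-out higher numbers stand for more inhibition at the one concentration tested (going by the name of the read-out) and lower numbers for less inhibition:
compound 1 `OCCNc1[nH]ccc2ncnc1-2` gives 3%
compound 2 `CN(C)c1[nH]ccc2ncnc1-2` gives 8%
compound 3 `CN(C)c1nccc2c1ncn2C1O[C@H](CO)[C@@H](O)[C@H]1O` gives 0%

All three numbers lie within the usual scatter of one another, so none of the three can be placed above or below the others on this read-out. Compound 1 and compound 2 share one core and differ in a single place: (2-hydroxyethyl)amino in place of dimethylamino on an aromatic carbon. This change gave a number 5 percentage points lower from compound 2 to compound 1 (within the scatter), a step that does not leave the scatter.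

Compound 3 carries a different core; how the cores of compound 2 and compound 3 differ is not broken down here. Compound 4 `OCCNc1nccc2c1ncn2C1O[C@H](CO)[C@@H](O)[C@H]1O` is the partner of compound 3 under the same change that connects compound 2 to compound 1: (2-hydroxyethyl)amino in place of dimethylamino on an aromatic carbon. The place is the same in both pairs, word for word, so this is the same change made on two cores.

The expectation for compound 4 rests on two things. First, the only measured instance of this change, a number 5 percentage points lower from compound 2 to compound 1 (within the scatter), stayed within the scatter. Second, compound 3 itself gives 0%. The step from compound 3 to compound 4 is therefore expected to be small, a number 2 percentage points higher from compound 3 to compound 4 (within the scatter). Compound 4 is expected to give 2% in this assay. The expected range for compound 4 runs from -8% to 12%, which also allows for negative readings that a near-zero compound can return. Nothing in the three measured compounds points to a higher number in this set, and the number for compound 4 is not expected to be higher either.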

Compound 4, a percentage reported as inhibition, at one concentration (the size of the read-out at that concentration, not a potency): 0%
Estimate against measurement, compound 4: 2 percentage points above; the range from low to high includes it.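

In this assay, (2-hydroxyethyl)amino in place of dimethylamino on an aromatic carbon gave no change at the digits printed from compound 3 to compound 4 (within the scatter), and the two instances of this change do not differ beyond what repeated measurements allow: the same change on two cores in this assay, a number 5 percentage points lower (within the scatter) from compound 2 to compound 1 and no change at the digits printed (within the scatter) from compound 3 to compound 4, 5 percentage points apart, within the scatter of two such steps. On these two cores, then, the change reads alike, with neither step leaving the scatter. Among the compounds shown here, this does not show that the change is without effect in general or that it would transfer to other cores, since the comparison rests on only two pairs, all four numbers are low, and a low number on both sides of a step leaves little room for any difference between cores to appear.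

Still open, going by these compounds, is whether a plain amino group or a longer chain such as (3-hydroxypropyl)amino, on the same aromatic carbon, would give a number beyond the scatter of these four compounds. Also open, on these data alone, is how the change would read on a core whose dimethylamino compound gives a clearly higher number on this read-out.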